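The source may report more compounds than this note shows. Statements on the series, on what has been measured and on what is new or still open speak of the compounds shown alone.

Of the compounds shown here, three have been measured, and a fourth remains to be tested. Compound 1 `COC(=O)C1=C(C)NC(=O)NC1c1cccc([N+](=O)[O-])c1` and compound 2 `CC1=C(C(=O)OC(C)C)C(c2cccc([N+](=O)[O-])c2)NC(=O)N1` share one core; compound 3 `COC(=O)C1=C(C)OC(N)=C(C(=O)OC(C)C)C1c1cccc([N+](=O)[O-])c1` and compound 4 `CC1=C(C(=O)OC(C)C)C(c2cccc([N+](=O)[O-])c2)C(C(=O)OC(C)C)=C(N)O1` share another. The difference between the two cores is not broken down here.

In an assay on HEK293 cells for antagonist activity at Voltage-dependent L-type calcium channel subunit alpha-1D (Rattus norvegicus), read by FLIPR (a higher number here means a weaker inhibitor, a lower number a stronger inhibitor), compound 1 gives 18900 nM. Compound 2 carries the change (isopropyl in place of methyl on an oxygen next to a carbonyl group), and in this assay compound 2 gives 46600 nM. The result is a 2.5-fold higher number from compound 1 to compound 2 (0.39 log units; beyond the scatter). Compound 3 is the most potent of the three measured compounds, and in this assay compound 3 gives 1820 nM, which sits well apart from both compound 1 and compound 2.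

Compound 4 differs from compound 3 by isopropyl in place of methyl on an oxygen next to a carbonyl group. For the measured compounds named here, this is the same change, at the same place, as the one that separates compound 1 from compound 2, although it is made on a different core. Going by the values given here, the only guidance available is the single earlier instance, so its direction and size are taken as the best guide. For compound 4 the expected step is a 2.5-fold higher number from compound 3 to compound 4 (0.39 log units; beyond the scatter), a modest weakening because of a 2.5-fold higher number from compound 1 to compound 2 (0.39 log units; beyond the scatter) observed on the other core. On that basis compound 4 is estimated at 4500 nM in this assay, with a plausible range from 1800 nM to 12000 nM, the breadth reflecting that the transfer of a step between cores is uncertain.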

Compound 4, half-maximal inhibitory concentration: 1390 nM
Beside the measured number, compound 4's estimate is 3.2-fold (0.51 log units) above it, and the stated range ends above it.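

In this assay isopropyl in place of methyl on an oxygen next to a carbonyl group gives a 1.3-fold lower number from compound 3 to compound 4 (0.12 log units; within the scatter) on the core of compound 3, so compound 3 and compound 4 cannot be told apart, whereas the same change gave a 2.5-fold higher number from compound 1 to compound 2 (0.39 log units; beyond the scatter) on the core of compound 1. For the compounds shown here, this rests on a single pair on each core, so it shows only that the step seen on one core was a poor guide to the step on the other here, and it does not show why the cores respond differently or what the change would do on any further core. Within those limits, the two steps disagree, and the change did not carry over from one core to the other in this series: the same change on two cores in this assay, a 2.5-fold higher number (0.39 log units; beyond the scatter) from compound 1 to compound 2 and a 1.3-fold lower number (0.12 log units; within the scatter) from compound 3 to compound 4, 3.2-fold (0.51 log units) apart, beyond the scatter of two such steps.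

The compounds shown carry only methyl or isopropyl on that oxygen, so it remains open how a longer chain such as butyl, or a carboxylic acid at that place, would read on either core. On these data alone, it also remains open whether the mismatch between the cores holds for changes of other kinds, such as an amine in place of the nitro group on the aryl ring.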